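Moving from an aryl to a thiophenylmethyl sulfone

A few compounds are considered here, and "the series" means these few. Any claim that something is new, unique, unknown or untested is made for them only; others in the source may bear on it.

Measured compounds:
- compound 1, `O=S(=O)(c1ccccc1F)c1cn(C2CCNC2)c2ncccc12`: 2 nM
- compound 2, `CN1CCC(n2cc(S(=O)(=O)c3ccccc3F)c3cccnc32)C1`: 5.6 nM
- compound 3, `CCN1CCC(n2cc(S(=O)(=O)c3cccc(Cl)c3)c3cccnc32)C1`: 3.3 nM

In an assay on HeLa cells for displacement of a labelled ligand from 5-hydroxytryptamine receptor 6 (Homo sapiens) (a lower number here means a stronger inhibitor, a higher number a weaker inhibitor), compound 1 gives 2 nM, the lowest of the three numbers. Compound 3 gives 3.3 nM, which lies within the scatter of compound 1, while compound 2 gives 5.6 nM. Among the measured compounds shown here, the one step between directly comparable compounds, a 2.8-fold higher number from compound 1 to compound 2 (0.45 log units; beyond the scatter), concerns the amine nitrogen of the shared core and says nothing about the group on the sulfonyl sulfur.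

Compound 4, `O=S(=O)(Cc1ccc(Cl)s1)c1cn(C2CCNC2)c2ncccc12`, differs from compound 1 in exactly that place: (5-chlorothiophen-2-yl)methyl in place of 2-fluorophenyl on a sulfonyl sulfur. For the measured compounds named here, no measured pair shows what such an exchange does here; compound 3 carries a different aryl group on the sulfonyl sulfur, but it also differs at the amine, so its value cannot be read as a step for this change alone.

Going by the values given here, with no comparable step to lean on, the estimate for compound 4 is 20 nM, with a range from 4 nM to 100 nM, and the expected step of a 10-fold higher number from compound 1 to compound 4 (1.00 log units; beyond the scatter) is a weakening in this assay, with wide uncertainty.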

Compound 4, inhibition constant: 1 nM
Compound 4: middle estimate off by 20-fold (1.30 log units), on the high side; measured number below the stated range.
By their numbers in this assay, from the lowest: compounds 4, 1, 3 and 2 (each within the scatter of the next, the first and the last beyond it).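

In this assay, putting (5-chlorothiophen-2-yl)methyl in place of 2-fluorophenyl on a sulfonyl sulfur gives a 2.0-fold lower number from compound 1 to compound 4 (0.30 log units; within the scatter) and so leaves the two compounds indistinguishable. Among the compounds shown here, this position therefore accepts more than the aryl groups of the earlier compounds: a five-membered aromatic ring with a sulfur atom, held on a methyl rather than bonded directly to the sulfonyl sulfur, does as well as 2-fluorophenyl. Nothing available here accounts for this tolerance. 

The compounds shown do not separate the contributions of the methyl, the thiophene ring and the chlorine, so a plain benzyl group or an unsubstituted (thiophen-2-yl)methyl group would be informative. On these data alone, it also remains open whether the exchange gives a similar result when the ring amine carries a methyl or ethyl group.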